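Butyl ether to hydroxy in the catechol glycoside series

The source may hold more compounds than are shown below. What is called first, only, known or untested is meant among the compounds shown, and "the series" means these compounds.

Compound 1 `CCCCO[C@H](c1ccc(O)c(O)c1)[C@H](CC#Cc1ccc(O)c(O)c1)O[C@@H]1O[C@H](CO)[C@@H](O)[C@H](O)[C@H]1O` gives 99% in a functional assay on heart right ventricle (Rattus norvegicus, strain WKY), tested at 0.3 uM; a lower number here means a stronger effect, a higher number a weaker effect of the compound at the concentration tested; compound 2 `CCCCO[C@@H](c1ccc(O)c(O)c1)[C@H](CC#Cc1ccc(O)c(O)c1)O[C@@H]1O[C@H](CO)[C@@H](O)[C@H](O)[C@H]1O` gives 102%, and the two numbers stand within the scatter of each other, a number 3 percentage points higher from compound 1 to compound 2 (within the scatter), the pair differing only in configuration as drawn (the fact that compounds 1 and 2 differ only in the configuration as drawn). Compound 3 `OC[C@H]1O[C@@H](O[C@@H](CC#Cc2ccc(O)c(O)c2)[C@H](O)c2ccc(O)c(O)c2)[C@H](O)[C@@H](O)[C@@H]1O` differs from compound 1 by hydrogen in place of butyl on an oxygen on a saturated carbon. Going by the values given here, no measured step touches this position; the only step known, a change of configuration, stayed within the scatter, so no step beyond the scatter is expected here either. Compound 3 is therefore expected at 99%, between 87% and 111%. The expected step is no change at the digits printed from compound 1 to compound 3 (within the scatter).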

Compound 3, a percentage reported as activity, at one concentration (the size of the read-out at that concentration, not a potency): 92.3%
Estimate against measurement, compound 3: 6.7 percentage points above; low and high end bracket the measured number.
By their numbers in this assay, from the lowest: compounds 3, 1 and 2 (each within the scatter of the next).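

In this assay, the butoxy to hydroxy change gives a number 6.7 percentage points lower from compound 1 to compound 3 (within the scatter). Going by these compounds alone, this is the first measured change of substituent on this oxygen, and removing the butyl group altogether produces no step beyond the scatter at the concentration tested. No available evidence bears on this particular change.

On these data alone, whether a longer chain, a benzyl group or a carboxylic acid on this oxygen would give a step beyond the scatter stays open. The compounds shown also leave open how the series behaves at other concentrations.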